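Replacing 2-methylphenyl with 4-cyanophenyl on a shared core

The source may report more compounds than this note shows. Statements on the series, on what has been measured and on what is new or still open speak of the compounds shown alone.

In a functional assay on SW-620 cells (Homo sapiens) for cytotoxicity, read by sulforhodamine B assay, with a stated time of 48 h (a higher number here means a weaker inhibitor, a lower number a stronger inhibitor), the measured compounds are:
- compound 1 `C[C@H]1CC[C@@H]2[C@@H](OC(=O)[C@]23CC(c2ccc(O)cc2)=NO3)[C@]2(C)C(=O)C=C[C@@]12O` with 89000 nM as its value
- compound 2 `Cc1ccccc1C1=NO[C@]2(C1)C(=O)O[C@@H]1[C@H]2CC[C@H](C)[C@]2(O)C=CC(=O)[C@@]12C` with 5000 nM as its value

Of these two, compound 2 holds the lower number and so is the stronger inhibitor. Compound 3 `C[C@H]1CC[C@@H]2[C@@H](OC(=O)[C@]23CC(c2ccc(C#N)cc2)=NO3)[C@]2(C)C(=O)C=C[C@@]12O` differs from compound 2 in one place, with 4-cyanophenyl in place of 2-methylphenyl on a carbon with a double bond to nitrogen in the shared core. Among the compounds with values here, the only measured step bearing on this is an 18-fold lower number from compound 1 to compound 2 (1.25 log units; beyond the scatter) and it involves the same carbon, so a change here can move the number a lot. Within the data shown here, no measurement yet covers a nitrile. The entering group carries its substituent at the 4 position, as does the 4-hydroxyphenyl of compound 1, so a partial move towards the higher number in this assay is expected. The expected size of that move is a 3.0-fold higher number from compound 2 to compound 3 (0.48 log units; beyond the scatter) as a moderate step. Compound 3 is estimated at 15000 nM with an expected range from 4000 nM to 60000 nM for the measurement.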

Compound 3, half-maximal inhibitory concentration: 53000 nM
Beside the measured number, compound 3's estimate is 3.5-fold (0.55 log units) below it, and the stated range covers the measured number.
By their numbers in this assay, from the lowest: compound 2; then compounds 3 and 1 (each within the scatter of the next).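

In this assay there is an 11-fold higher number from compound 2 to compound 3 (1.03 log units; beyond the scatter) when 4-cyanophenyl takes the place of 2-methylphenyl, so the large drop seen earlier at this carbon is not a general result of changing the 4-hydroxyphenyl group. Swapping hydroxy for cyano on the aromatic carbon gives a 1.7-fold lower number from compound 1 to compound 3 (0.23 log units; within the scatter) and therefore no real difference between these two 4-substituted phenyl groups, leaving 2-methylphenyl as the only one of the three that stands apart. No measurement shown explains why this carbon responds in this way.

Still open, going by these compounds, is whether the methyl group itself or its place on the ring matters, a question that 4-methylphenyl and 2-cyanophenyl could separate. Also open, on these data alone, is how unsubstituted phenyl, or a phenyl ring carrying an amine or a carboxylic acid, would compare on the shared core.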